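The source may report more compounds than this note shows. Statements on the series, on what has been measured and on what is new or still open speak of the compounds shown alone.

Measured compounds:
compound 1 `COc1ccc(S(=O)(=O)c2cnc3ccc(F)cc3c2N2CCC(C)CC2)cc1` — 85%
compound 2 `Cc1ccc2ncc(S(=O)(=O)c3ccc(F)cc3)c(N3CCC(C)CC3)c2c1` — 90%
compound 3 `CC1CCN(c2c(S(=O)(=O)c3ccc(Cl)c(Cl)c3)cnc3ccc(Cl)cc23)CC1` — 86%

Three compounds sharing one core were tested in an assay on isolated protein for displacement of a labelled ligand from metabotropic glutamate receptor 5 (Homo sapiens), with a stated time of 60 min, tested at 1 uM; on this read-out higher numbers stand for more inhibition at the one concentration tested (going by the name of the read-out) and lower numbers for less inhibition. In this assay compound 1 gives 85%, compound 2 gives 90% and compound 3 gives 86%. Compound 2 has the highest of the three numbers, yet the gaps to compound 3 and to compound 1 both lie within the usual scatter of such measurements, so the three cannot be ordered against one another on these data.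

Compound 4 `COc1ccc(S(=O)(=O)c2cnc3ccc(C)cc3c2N2CCC(C)CC2)cc1` has not yet been measured. It differs from compound 2 in one place: methoxy in place of fluoro on an aromatic carbon. The resulting 4-methoxyphenyl is the same group that compound 1 carries on its core, and compound 1 gives 85% in this assay, a number within the scatter of what compound 2 gives. On that basis no step beyond the scatter is expected; the change a number 4 percentage points lower from compound 2 to compound 4 (within the scatter) is estimated to be small in either direction. Compound 4 is expected to give about 86% in this assay, with a likely range from 75% to 94%.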

Compound 4, a percentage reported as inhibition, at one concentration (the size of the read-out at that concentration, not a potency): 62%
Estimate against measurement, compound 4: 24 percentage points above, and the stated range ends above it.
By their numbers in this assay, from the lowest: compound 4; then compounds 1, 3 and 2 (each within the scatter of the next).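

In this assay, replacing 4-fluorophenyl with 4-methoxyphenyl on a core carrying methyl gives a number 28 percentage points lower from compound 2 to compound 4 (beyond the scatter), so this position does respond to the change. The earlier high number for compound 1 therefore does not carry over to every compound with 4-methoxyphenyl: with that group kept, exchanging the fluoro of the core for methyl gives a number 23 percentage points lower from compound 1 to compound 4 (beyond the scatter) in this assay. Nothing shown here explains why either step occurs.

The compounds shown leave open whether ethoxy, hydroxy or an amine at the position of the methoxy would give a similarly low number. They also leave open whether chloro or methoxy in place of the methyl on the core would restore the number while 4-methoxyphenyl stays.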